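Aryl replacement on the thiazole-bearing acid series

The source may report more compounds than this note shows. Statements on the series, on what has been measured and on what is new or still open speak of the compounds shown alone.

Measured so far:
compound 1 `Cc1nc(-c2ccsc2)sc1COc1ccc2c(c1)OCC2CC(=O)O` — 68.5 nM
compound 2 `Cc1ccccc1-c1nc(C)c(COc2ccc3c(c2)OCC3CC(=O)O)s1` — "not determined" (no result reported)

Within the data shown here, compound 1 is the only member of the pair with a number in a functional assay on CHO cells for agonist activity at Free fatty acid receptor 1 (Homo sapiens), read by FLIPR and calcium flux; a higher number here means that more compound is needed for the effect, a lower number that less compound is needed. Among the measured compounds shown here, compound 2 carries the 2-methylphenyl group on the shared core; for compound 2 the result in this assay is recorded as "not determined" (no result reported), so compound 2 has no figure to stand on and no step from it can be sized.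

Compound 3 `Cc1nc(-c2cccc(Cl)c2)sc1COc1ccc2c(c1)OCC2CC(=O)O` is the next member to be tested. Relative to compound 2 the change is 3-chlorophenyl in place of 2-methylphenyl on an aromatic carbon. With no number for compound 2, the expectation for compound 3 in this assay rests on compound 1 alone: a result in the same general range as 68.5 nM is anticipated, and no change beyond the usual scatter is predicted in either direction.

Compound 3 is expected to give about 60 nM in this assay, with a likely range of 12 nM to 300 nM.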

Compound 3, half-maximal effective concentration: 138 nM
Beside the measured number, compound 3's estimate is 2.3-fold (0.36 log units) below it, within the range that was stated.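

In this assay, putting 3-chlorophenyl in place of thiophen-3-yl on this aromatic carbon of the five-membered aromatic ring gives a 2.0-fold higher number from compound 1 to compound 3 (0.30 log units; within the scatter), so a chlorine-bearing six-membered aromatic ring and the five-membered thiophen-3-yl cannot be told apart here. The step from compound 2 to compound 3 cannot be read, since compound 2 has no number. No measured evidence bears on why these two aryl groups read alike.

Still open, from the compounds shown here alone, is where the 2-methylphenyl group of compound 2 would fall relative to these two groups. The compounds shown also leave untested whether the same reading would hold for a pyridyl group or for a phenyl ring carrying an amine or a carboxylic acid at this position.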